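The source may hold more compounds than are shown below. What is called first, only, known or untested is meant among the compounds shown, and "the series" means these compounds.

Of the compounds shown here, two built on a shared core have so far been tested in a functional assay for inhibition, read by spectrophotometry, with a stated time of 30 min, tested at 1 uM; a higher number here means more inhibition at the concentration tested (going by the name of the read-out), a lower number less inhibition. Compound 1 `CCCNC(=C\C(=O)/C=C/c1ccc(O)c(OC)c1)/C=C/c1ccc(O)c(OC)c1` gives 0.1% in this assay. Compound 2 `CCC(C)NC(=C\C(=O)/C=C/c1ccc(OC(C)=O)c(OC)c1)/C=C/c1ccc(OC(C)=O)c(OC)c1` gives 0% in this assay. Compound 1 carries the larger of the two numbers, but its gap to compound 2 lies within the scatter, so no order can be read from the pair; both show essentially no inhibition at the concentration tested. Compound 3 `C=CCNC(=C\C(=O)/C=C/c1ccc(O)c(OC)c1)/C=C/c1ccc(O)c(OC)c1` has not yet been measured in this assay. It differs from compound 1 in one place: vinyl in place of ethyl on a saturated chain carbon bound to an amine nitrogen. Among the compounds with values here, no step between measured compounds is available to guide this change. Because compound 1 gives 0.1% and compound 2 gives 0%, the expected step is a number 0.4 percentage points higher from compound 1 to compound 3 (within the scatter), none beyond the scatter in either direction. Compound 3 is therefore estimated to give 0.5% in this assay, with a range from 0% to 8%.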

Compound 3, a percentage reported as inhibition, at one concentration (the size of the read-out at that concentration, not a potency): 0.1%
For compound 3 the middle estimate is 0.4 percentage points above the measured one; the range from low to high includes it.
By their numbers in this assay, from the lowest: compounds 2, 1 and 3 (each within the scatter of the next).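

In this assay vinyl in place of ethyl on a saturated chain carbon bound to an amine nitrogen gives no change at the digits printed from compound 1 to compound 3 (within the scatter). Within the data shown here, this is the first step that can be read at this place, and it shows that going from propylamino to allylamino leaves the compound with essentially no inhibition at the concentration tested, so the step joins two compounds that both sit at the floor of the read-out and says little about how sensitive this place could be in a compound that inhibits. Nothing available bears on the reason for this result.

Among these compounds, compound 2 differs from the other two compounds in more than one place, so no step involving it can be read. Still open, as far as these compounds go, is whether a longer chain, a benzyl group or a carboxylic acid on the amine nitrogen would produce any measurable inhibition on the shared core.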